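Resolving the ring stereocentre in the fluoro analogue

A few compounds are considered here, and "the series" means these few. Any claim that something is new, unique, unknown or untested is made for them only; others in the source may bear on it.

Compound 3 `NC(=S)N1N=C(c2ccc(F)cc2)CC1c1ccc(Cl)cc1` gives 6 nM in an assay on mitochondria for inhibition of Amine oxidase [flavin-containing] A (Bos taurus) (a lower number here means a stronger inhibitor, a higher number a weaker inhibitor), the lowest number of the three measured; compound 2 `Cc1ccc(C2=NN(C(N)=S)[C@@H](c3ccc(Cl)cc3)C2)cc1` gives 13 nM and compound 1 `Cc1ccc(C2=NN(C(N)=S)C(c3ccc(Cl)cc3)C2)cc1` gives 31 nM in this assay. Compound 4 `NC(=S)N1N=C(c2ccc(F)cc2)C[C@@H]1c1ccc(Cl)cc1` differs from compound 3 only in that (the two compounds have the same atoms and bonds; at least one stereo element is drawn with a configuration in one of them and without one in the other: 1 of 1 stereo elements differ; a stereocentre at a saturated ring carbon is drawn without a configuration in compound 3 and R in compound 4). The same kind of step is already measured: a 2.4-fold lower number from compound 1 to compound 2 (0.38 log units; beyond the scatter), which is accounted for by the fact that one of compounds 1 and 2 is drawn with a defined configuration and the other without, at the place where they differ. The change from compound 1 to compound 3 was a 5.2-fold lower number from compound 1 to compound 3 (0.71 log units; beyond the scatter), but it concerns the fluoro, not the stereocentre, so it does not bear here. A modest lowering of a similar size is therefore expected for compound 4, estimated at a 2.0-fold lower number from compound 3 to compound 4 (0.30 log units; within the scatter). Compound 4 is expected to give 3 nM in this assay, within 1.2 nM to 7 nM.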

Compound 4, inhibition constant: 12 nM
Beside the measured number, compound 4's estimate is 4.0-fold (0.60 log units) below it, and the stated range ends below it.
By their numbers in this assay, from the lowest: compounds 3, 4 and 2 (each within the scatter of the next, the first and the last beyond it); then compound 1.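

In this assay, drawing the R configuration at the ring carbon does not give the same result on the two cores: a 2.0-fold higher number from compound 3 to compound 4 (0.30 log units; within the scatter) does not repeat a 2.4-fold lower number from compound 1 to compound 2 (0.38 log units; beyond the scatter). Fluoro in place of methyl on an aromatic carbon also reads differently with the configuration drawn, a 1.1-fold lower number from compound 2 to compound 4 (0.03 log units; within the scatter), than without it: the same change on two cores in this assay, a 5.2-fold lower number (0.71 log units; beyond the scatter) from compound 1 to compound 3 and a 1.1-fold lower number (0.03 log units; within the scatter) from compound 2 to compound 4, 4.8-fold (0.68 log units) apart, beyond the scatter of two such steps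

The compounds shown leave open how the S configuration at this ring carbon reads. They also leave open whether a methoxy group or a nitrile in place of the fluoro would follow the fluoro steps.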